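The source may hold more compounds than are shown below. What is called first, only, known or untested is meant among the compounds shown, and "the series" means these compounds.

In a physicochemical assay for solubility, in phosphate buffer, at pH 7.4 (a higher number here means a more soluble compound, a lower number a less soluble compound), compound 1 `CCOC(=O)c1c(-c2cccc(F)c2)[nH]c2cccc(OC)c2c1=O` gives > 100000 nM as a limit of the assay and not a number. Compound 2 `CCOC(=O)c1c(-c2ccccc2)[nH]c2cccc(OC)c2c1=O` gives > 100000 nM as a limit too. Going by the values given here, compound 3 `CCOC(=O)c1c(-c2cccc(OC)c2)[nH]c2cccc(OC)c2c1=O` gives > 100000 nM as a limit also, which places it at the limit of > 100000 nM in this assay, at which 3 of the 3 values shown sit, for the series so far. Compound 4 `CCOC(=O)c1c(-c2cccc(C(F)(F)F)c2)[nH]c2cccc(OC)c2c1=O` differs from compound 3 by trifluoromethyl in place of methoxy on an aromatic carbon with trifluoromethyl in place of methoxy on an aromatic carbon. The exchanges bearing on this are a step that the two limits leave unreadable from compound 1 to compound 2 and a step that the two limits leave unreadable from compound 1 to compound 3 and a step that the two limits leave unreadable from compound 2 to compound 3 and none of them gives a size. No shift beyond the scatter is therefore expected in this assay and the expected change is a number no higher from compound 3 to compound 4 (the limit leaves the size open) for now. For compound 4 the estimated value is 100000 nM within an expected range of 40000 nM to 200000 nM and only a limit may again be expected.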

Compound 4, solubility: > 100000 nM
Compound 4 ended at the assay's limit; the forecaster's own chance of this, stated with the estimate: 70%; the middle value lies on the limit itself.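

Compound 4 gives > 100000 nM in this assay, a limit of the assay and not a number. Its steps to compound 1, compound 2 and compound 3 therefore cannot be read. The compounds shown leave open whether exchanging the group on the aromatic carbon changes the read-out at all.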